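The source may report more compounds than this note shows. Statements on the series, on what has been measured and on what is new or still open speak of the compounds shown alone.

Measured in a functional assay on DLD-1 cells (Homo sapiens) for antiproliferative activity, read by CellTiter-Glo, with a stated time of 72 h; a lower number here means a stronger inhibitor, a higher number a weaker inhibitor:
- compound 1 `Cc1cc(C)c(S(=O)(=O)N2CCC(N3CCC(C)CC3)CC2)c(C)c1`: 0.03 nM
- compound 2 `CC1CCN(C2CCN(S(=O)(=O)c3cccc(N)c3)CC2)CC1`: 3400 nM

Compound 2 holds the higher of the two numbers, at 3400 nM, and the gap to compound 1 at 0.03 nM lies well beyond the scatter. Compound 3 `Cc1cccc(S(=O)(=O)N2CCC(N3CCC(C)CC3)CC2)c1` follows from compound 2 by one change, methyl in place of amino on an aromatic carbon, meta to a large group. Within the data shown here, no measured pair isolates this change, so the expectation is loose. Methyl on the aromatic ring also occurs in compound 1, at 0.03 nM. A lower number beyond the scatter is expected, an estimated step of a 34-fold lower number from compound 2 to compound 3 (1.53 log units; beyond the scatter). For compound 3 the estimate is 100 nM, with an expected range of 5 nM to 1500 nM.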

Compound 3, half-maximal inhibitory concentration: 25 nM
The estimate for compound 3 lay 4.0-fold (0.60 log units) above the measured number; measured number inside the range.
By their numbers in this assay, from the lowest: compound 1; then compound 3; then compound 2.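

In this assay, among these compounds, methyl in place of amino on this aromatic carbon, meta to a large group, gives a 140-fold lower number from compound 2 to compound 3 (2.13 log units; beyond the scatter) as the first step that isolates one place. A single heavy atom at this position is therefore enough to move the number far beyond the scatter, with the hydrogen-bond donor and acceptor of amino gone. No measurement at hand speaks to the cause of this step.

From the compounds shown here alone, whether the step comes from losing amino or from gaining methyl stays open. Hydroxyl, methoxy or chlorine on the same carbon would separate the two.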